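Dimethylsulfamoyl in Place of Aminomethyl in a Cytotoxic Series

The source may report more compounds than this note shows. Statements on the series, on what has been measured and on what is new or still open speak of the compounds shown alone.

In a functional assay on PC-6 cells (Homo sapiens) for cytotoxicity, read by MTT assay, with a stated time of 3 days (on this read-out higher numbers stand for weaker inhibition and lower numbers for stronger inhibition), compound 1 (`CC(C)(C)c1cc2c(N/N=C/c3ccc(CN)cc3)ncnc2s1`) gives 0.214 ug/mL and stands highest of the two measured numbers. Compound 2 (`CC(C)(C)c1cc2c(N/N=C/c3ccc4c(c3)CNC4)ncnc2s1`) gives 0.071 ug/mL on the same read-out, a gap beyond the scatter. Compound 3 (`CN(C)S(=O)(=O)c1ccc(/C=N/Nc2ncnc3sc(C(C)(C)C)cc23)cc1`) keeps the core of compound 1 and differs from it in one place: dimethylsulfamoyl in place of aminomethyl on an aromatic carbon. Among the compounds with values here, no measured pair shows this change and no measured compound carries dimethylsulfamoyl, so any forecast remains cautious. In this assay a moderate step toward a higher number, meaning weaker inhibition, is expected, although a step within the scatter cannot be excluded. The estimate amounts to an expected 2.8-fold higher number from compound 1 to compound 3 (0.45 log units; beyond the scatter) and remains rough. Compound 3 is expected at 0.6 ug/mL (0.15 ug/mL to 2.5 ug/mL as the estimated range).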

Compound 3, half-maximal inhibitory concentration: 2.12 ug/mL
Compound 3: the middle estimate sits 3.5-fold (0.55 log units) below what was measured, and the stated range covers the measured number.
By their numbers in this assay, from the lowest: compound 2; then compound 1; then compound 3.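

In this assay, the place on the aromatic carbon para to a large group proves sensitive to this exchange: dimethylsulfamoyl in place of aminomethyl gives (a 9.9-fold higher number from compound 1 to compound 3 (1.00 log units; beyond the scatter)), a clear move toward weaker inhibition. The earlier compounds shown here varied only how the amine was held and did not show what happens when aminomethyl is removed altogether. The entering group has no hydrogen-bond donor and more heavy atoms than aminomethyl, but this single pair cannot separate those differences, and nothing measured here gives a reason for the step.

On these data alone, it remains open whether the loss follows from removing the amine nitrogen or from adding the sulfonyl unit. A primary sulfonamide, a dimethylaminomethyl group or a longer aminoalkyl chain at this place would help to tell these apart.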